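The compounds below may be only part of what the source reports. "The series", "measured", "known", "first", "only" and "open" are said of these compounds alone.

In a functional assay on HepG2 cells (Homo sapiens) for inhibition, read by MTT assay, with a stated time of 48 h (on this read-out lower numbers stand for stronger inhibition and higher numbers for weaker inhibition), three compounds built on one shared core have been measured. Compound 1 `COc1ccc(N(C)c2nc(C)nc3ccccc23)cc1OCCN` gives 343 nM. Compound 2 `COc1ccc(N(C)c2nc(C)nc3ccccc23)cc1C(=O)OCCC[Se]C#N` gives 340 nM, and compound 3 `COc1ccc(N(C)c2nc(C)nc3ccccc23)cc1[Se]C#N` gives 59 nM. Compound 2 therefore stands second highest of the three numbers: it and compound 1 lie within the usual scatter of each other, shown by a 1.0-fold lower number from compound 1 to compound 2 (0.00 log units; within the scatter), while the step of a 5.8-fold lower number from compound 2 to compound 3 (0.76 log units; beyond the scatter) is beyond the scatter and modest, as is a 5.8-fold lower number from compound 1 to compound 3 (0.76 log units; beyond the scatter).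

Compound 4 `COc1ccc(N(C)c2nc(C)nc3ccccc23)cc1C(=O)OCCCCCC[Se]C#N` is not yet measured in this assay. It differs from compound 2 by a group of 6 heavy atoms (4 carbon, 1 nitrogen, 1 selenium; no ring) in place of a group of 3 heavy atoms (1 carbon, 1 nitrogen, 1 selenium; no ring), on a saturated chain carbon, three bonds along the chain from an oxygen next to a carbonyl group. Among the compounds with values here, no measured step concerns a change on a saturated chain carbon; every one of them concerns an exchange on an aromatic carbon. The nearest guide is the step from compound 1 to compound 2, where a large exchange of groups left the number unchanged within the scatter. A step of no more than the scatter is therefore expected in this assay for compound 4, in no particular direction. Compound 4 is expected to give about 340 nM, within a range from 150 nM to 800 nM, which means an expected step of no change at the digits printed from compound 2 to compound 4 (within the scatter).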

Compound 4, half-maximal inhibitory concentration: 2650 nM
The estimate for compound 4 lay 7.8-fold (0.89 log units) below the measured number, outside the stated range (above it).
By their numbers in this assay, from the lowest: compound 3; then compounds 2 and 1 (each within the scatter of the next); then compound 4.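

In this assay, the change on a saturated chain carbon, three bonds along the chain from an oxygen next to a carbonyl group, brings a 7.8-fold higher number from compound 2 to compound 4 (0.89 log units; beyond the scatter). The entering group differs from the leaving group only in its carbon count, with the same nitrogen, selenium and triple bond, so the number at this position responds to the size of the chain alone, something the earlier exchanges on an aromatic carbon could not show. Nothing measured here says why the higher number arises.

As far as these compounds go, compound 2 and compound 4 give only two points along this chain, so it remains open whether the number climbs steadily with length or jumps at one point. A longer chain would help to settle this, and an amine at the chain end would show whether the selenium-bearing end is needed at all.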